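A few compounds are considered here, and "the series" means these few. Any claim that something is new, unique, unknown or untested is made for them only; others in the source may bear on it.

Working notes on the series, read in a functional assay on A549 cells (Homo sapiens) for cytotoxicity, read by MTT assay, with a stated time of 72 h; a lower number here means a stronger inhibitor, a higher number a weaker inhibitor: compound 1 `O=C1c2c[n+]([O-])c3ccccc3c2C(=O)c2c1c1ccccc1n2Cc1cn(C[C@H](O)CO)nn1` gives 1030 nM and compound 2 `O=C1c2c[n+]([O-])c3ccccc3c2C(=O)c2c1c1ccccc1n2CCN1CCCCC1` gives 1080 nM, so compound 1 stands level with the only other measured compound. Compound 3 `O=C1c2c[n+]([O-])c3ccccc3c2C(=O)c2c1c1ccccc1n2Cc1cn([C@@H]2O[C@H](CO)[C@@H](O)[C@H](O)[C@H]2O)nn1` carries 3,4,5-trihydroxy-6-(hydroxymethyl)oxan-2-yl in place of 2,3-dihydroxypropyl on an aromatic nitrogen. Among the compounds with values here, the one measured step, a 1.0-fold higher number from compound 1 to compound 2 (0.02 log units; within the scatter), replaces the whole side group, and no measured step covers this exchange itself. Within the data shown here, that step gives the only guide, so the expected move, a 1.3-fold higher number from compound 1 to compound 3 (0.10 log units; within the scatter), is none beyond the scatter, in either direction. For compound 3 the estimated value is 1300 nM, with an expected range of 450 nM to 3800 nM.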

Compound 3, half-maximal inhibitory concentration: 560 nM
Estimate against measurement, compound 3: 2.3-fold (0.37 log units) above; the range from low to high includes it.
By their numbers in this assay, from the lowest: compounds 3, 1 and 2 (each within the scatter of the next).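

In this assay, the aromatic nitrogen of the five-membered aromatic ring with 3 nitrogen takes 3,4,5-trihydroxy-6-(hydroxymethyl)oxan-2-yl in place of 2,3-dihydroxypropyl, with a 1.8-fold lower number from compound 1 to compound 3 (0.26 log units; within the scatter). Going from 5 heavy atoms and no ring to 11 heavy atoms and one six-membered non-aromatic ring thus leaves the number within the scatter, a change at this nitrogen alone that the earlier pair did not isolate. Nothing available accounts for this result. Open, as far as these compounds go, is whether an amine, a carboxylic acid or a longer chain on this nitrogen would also stay within the scatter.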